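Shortening the ether chain of compound 1

This account rests on a few compounds, and the source may have more. Where it says the series, first, only, none or still open, it means among the compounds named here.

Measured compounds:
compound 1 `CCCCCCOc1ccc2c(Cl)ccnc2c1` gives 2440 nM
compound 2 `Clc1ccnc2cc(OCc3ccccc3)ccc12` gives 2470 nM
compound 3 `CCCCCCOc1ccc2c(NCCN(C)C)ccnc2c1` gives 850 nM

These three compounds were tested in a functional assay on HCT-116 cells (Homo sapiens) for cytotoxicity, read by MTT assay, with a stated time of 48 h; a higher number here means a weaker inhibitor, a lower number a stronger inhibitor. Compound 1 stands second highest of the three numbers; compound 2 lies closest to it, and the two differ only within the scatter. Compound 3 lies furthest away with the lowest number.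

Compound 4 `CC(C)Oc1ccc2c(Cl)ccnc2c1` is not yet measured. It differs from compound 1 in one place: isopropyl in place of hexyl on an oxygen on an aromatic ring.

Two measured steps start from compound 1. The step of a 1.0-fold higher number from compound 1 to compound 2 (0.01 log units; within the scatter) changes the group on the same ether oxygen and leaves the number essentially unchanged. The step of a 2.9-fold lower number from compound 1 to compound 3 (0.46 log units; beyond the scatter) alters a different place, the chloro position, and gives a modest decrease; it does not speak to the change in compound 4. Only the first step bears on the ether chain, and it suggests tolerance there, so no step beyond the scatter is expected for compound 4. Compound 4 is therefore estimated at 2600 nM, within 1200 nM to 5600 nM, which means an expected step of a 1.1-fold higher number from compound 1 to compound 4 (0.03 log units; within the scatter).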

Compound 4, half-maximal inhibitory concentration: 2590 nM
Compound 4: middle estimate off by 1.0-fold (0.00 log units), on the high side, within the range that was stated.
By their numbers in this assay, from the lowest: compound 3; then compounds 1, 2 and 4 (each within the scatter of the next).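

Replacing hexyl with isopropyl on the ether oxygen in this assay gives a 1.1-fold higher number from compound 1 to compound 4 (0.03 log units; within the scatter), so a much smaller, branched chain of 3 carbon atoms is tolerated here just as hexyl is. Among the compounds shown here, the earlier step of a 1.0-fold higher number from compound 1 to compound 2 (0.01 log units; within the scatter) covered only a group carrying a phenyl ring; together, the two steps show that neither an added ring nor a shorter alkyl group moves the number beyond the scatter, and no compound that differs from compound 1 at this oxygen goes against that. No evidence is available to explain this steadiness.

The compounds shown leave open whether an ether group carrying an amine or a carboxylic acid would behave the same way. They also leave open whether isopropyl or the phenyl-bearing group would match hexyl with the (2-(dimethylamino)ethyl)amino group of compound 3 in place of chloro.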